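The source may hold more compounds than are shown below. What is called first, only, known or untested is meant among the compounds shown, and "the series" means these compounds.

Working notes on the series. In a functional assay, with a stated time of 20 min (on this read-out higher numbers stand for weaker inhibition and lower numbers for stronger inhibition), compound 1 (`CC(C)[C@@H]1CC[C@@H](C)C[C@@]12N(C)C(=O)[C@@H]1[C@H]3C(=O)NC(=O)[C@H]3ON12`) gives 1550 ug/mL and compound 2 (`CC(C)[C@@H]1CC[C@@H](C)C[C@@]12N(C)C(=O)[C@@H]1[C@H]3C(=O)N(c4ccccc4)C(=O)[C@H]3ON12`) gives 900 ug/mL. Among the measured compounds shown here, these are the only two numbers so far, and they lie within the scatter of each other, so compound 1 has no clear rank. Compound 3 (`CC(C)[C@@H]1CC[C@@H](C)C[C@@]12N(C)C(=O)[C@@H]1[C@H]3C(=O)N(c4ccc5ccccc5c4)C(=O)[C@H]3ON12`) keeps the core of compound 1, with naphthalen-2-yl in place of hydrogen on an amide-type nitrogen in a ring.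

For the measured compounds named here, one measured step bears on this change at the same place: a 1.7-fold lower number from compound 1 to compound 2 (0.24 log units; within the scatter), with phenyl in place of the same hydrogen. Going by the values given here, no naphthalen-2-yl compound has been measured yet, and a single step within the scatter sets no firm trend. In this assay, a small move toward a lower number is therefore expected from compound 2's step, of about the same size and not clearly beyond the scatter. The expected step is a 1.8-fold lower number from compound 1 to compound 3 (0.26 log units; within the scatter). The estimate for compound 3 is 850 ug/mL, with an expected range from 350 ug/mL to 1700 ug/mL.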

Compound 3, half-maximal inhibitory concentration: 2920 ug/mL
Estimate against measurement, compound 3: 3.4-fold (0.54 log units) below, outside the stated range (above it).
By their numbers in this assay, from the lowest: compounds 2, 1 and 3 (each within the scatter of the next, the first and the last beyond it).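

At the amide-type nitrogen in a ring, the replacement of hydrogen by naphthalen-2-yl in this assay gives a 1.9-fold higher number from compound 1 to compound 3 (0.28 log units; within the scatter), so this change, like the phenyl replacement, does not separate from the parent compound beyond the scatter. The choice of group at this position does register, however: exchanging phenyl for naphthalen-2-yl gives a 3.2-fold higher number from compound 2 to compound 3 (0.51 log units; beyond the scatter), a modest step and the first in the series to lie beyond the scatter. The comparison therefore shows that the second six-membered aromatic ring of naphthalen-2-yl goes with a readable difference from phenyl, although nothing at hand accounts for that difference.

On these data alone, it remains open whether any group at this nitrogen can move the number beyond the scatter from compound 1, for instance a benzyl group, a short chain ending in an amine, or one ending in a carboxylic acid. Three compounds also cannot show whether the gap between phenyl and naphthalen-2-yl belongs to a wider trend, which naphthalen-1-yl or a substituted phenyl such as 4-methoxyphenyl could help to test.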